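This account rests on a few compounds, and the source may have more. Where it says the series, first, only, none or still open, it means among the compounds named here.

Three acylthioureas share one core. In a functional assay on A549 cells (Homo sapiens) for inhibition, read by CCK-8 assay, with a stated time of 48 h (on this read-out lower numbers stand for stronger inhibition and higher numbers for weaker inhibition), compound 1 `O=C(NC(=S)Nc1ccc(F)cc1)c1cn(-c2ccccc2)nc1-c1ccccc1` gives 3500 nM, compound 2 `O=C(NC(=S)Nc1ccc(Cl)cc1)c1cn(-c2ccccc2)nc1-c1ccc(Cl)cc1` gives 3150 nM and compound 3 `O=C(NC(=S)Nc1ccc(Cl)cc1)c1cn(-c2ccccc2)nc1-c1ccc(F)cc1` gives 2990 nM. Compound 3 carries the lowest of the three numbers, but both other values lie within the scatter of it, so no order among the three can be read. Among the measured compounds shown here, the only single-point change measured so far, a 1.1-fold lower number from compound 2 to compound 3 (0.02 log units; within the scatter), left the read-out essentially unchanged. Compound 4 `O=C(NC(=S)Nc1ccc(Cl)cc1)c1cn(-c2ccccc2)nc1-c1ccccc1` differs from compound 3 by hydrogen in place of fluoro on an aromatic carbon. For the measured compounds named here, no measured step removes a halogen at this position; the one halogen swap available stayed inside the scatter, and compounds 1 and 3, which carry different halogen patterns, give numbers close to each other. The step of a 1.1-fold higher number from compound 3 to compound 4 (0.03 log units; within the scatter) is therefore expected to stay within the scatter. Compound 4 is estimated at 3200 nM, with a range from 1600 nM to 6400 nM.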

Compound 4, half-maximal inhibitory concentration: 3200 nM
Compound 4: middle estimate and measured number agree at the digits printed, and the stated range covers the measured number.
By their numbers in this assay, from the lowest: compounds 3, 2, 4 and 1 (each within the scatter of the next).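

In this assay, this position tolerates loss of its halogen: 4-fluorophenyl to phenyl gives a 1.1-fold higher number from compound 3 to compound 4 (0.03 log units; within the scatter), and hydrogen in place of chloro gives a 1.0-fold higher number from compound 2 to compound 4 (0.01 log units; within the scatter). Hydrogen, fluoro and chloro here therefore cannot be told apart on this read-out. Chloro in place of fluoro on the other halogen-bearing ring gives a 1.1-fold lower number from compound 1 to compound 4 (0.04 log units; within the scatter), and the halogen swap now reads alike in two settings: the same change on two cores in this assay, a 1.1-fold lower number (0.02 log units; within the scatter) from compound 2 to compound 3 and a 1.1-fold higher number (0.04 log units; within the scatter) from compound 4 to compound 1, 1.2-fold (0.06 log units) apart, within the scatter of two such steps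

From the compounds shown here alone, whether an amine, a carboxylic acid or a longer chain at this position would move the number stays open.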